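Chloro added to the aryl ring of a triazine urea

The source may hold more compounds than are shown below. What is called first, only, known or untested is meant among the compounds shown, and "the series" means these compounds.

Compound 1 `CC1(C)N=C(N)N=C(N)N1c1ccc(OCc2ccc(S(=O)(=O)F)cc2)c(Cl)c1` gives 7.58 in an assay on isolated protein for inhibition of Dihydrofolate reductase (Mus musculus) (on this read-out lower numbers stand for lower potency and higher numbers for higher potency (the scale is a negative logarithm)), and compound 2 `CC1(C)N=C(N)N=C(N)N1c1ccc(OCc2ccc(S(=O)(=O)F)cc2Cl)c(Cl)c1` gives 7.44. The change between them is chloro in place of hydrogen on an aromatic carbon, and it made a step of a number 0.14 log units lower from compound 1 to compound 2 (within the scatter). Compound 3 `CC1(C)N=C(N)N=C(N)N1c1ccc(OCCCNC(=O)Nc2cccc(S(=O)(=O)F)c2)cc1` gives 7.32 in this assay; the difference between its core and that of compound 1 is not broken down here. Compound 4 `CC1(C)N=C(N)N=C(N)N1c1ccc(OCCCNC(=O)Nc2cccc(S(=O)(=O)F)c2)c(Cl)c1` is not yet measured; it differs from compound 3 by chloro in place of hydrogen on an aromatic carbon. This is the same kind of change as from compound 1 to compound 2, though there the new chloro sat meta to a fluorosulfonyl group, here meta to a large group. The step of a number 0.07 log units lower from compound 3 to compound 4 (within the scatter) is expected to be small, because a number 0.14 log units lower from compound 1 to compound 2 (within the scatter) lay within the scatter. For compound 4 the estimate is 7.25, between 6.85 and 7.65.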

Compound 4, logarithm of the reciprocal of the active concentration, log(1/C): 7.28
Beside the measured number, compound 4's estimate is 0.03 log units below it; the range from low to high includes it.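

Chloro in place of hydrogen on an aromatic carbon gave a number 0.04 log units lower from compound 3 to compound 4 (within the scatter) in this assay and so behaved as it had on the core of compound 1. Among the compounds shown here, this shows only that the change left the number within the scatter on these two cores in this one assay; it does not show that the same would hold on any other core. The two steps agree with each other: the same change on two cores in this assay, a number 0.14 log units lower (within the scatter) from compound 1 to compound 2 and a number 0.04 log units lower (within the scatter) from compound 3 to compound 4, 0.10 log units apart, within the scatter of two such steps

The compounds shown leave open whether fluoro, methyl or methoxy in place of chloro would behave the same way. They also leave open whether the agreement would hold on a core carrying an amine or a longer chain in place of the urea.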